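This account rests on a few compounds, and the source may have more. Where it says the series, first, only, none or still open, it means among the compounds named here.

Measured in an ADME assay on MRC5 cells (Homo sapiens), read by MTT assay, with a stated time of 72 h; a lower number here means a stronger inhibitor, a higher number a weaker inhibitor:
- Compound 1 `CN(C)c1ncnc2c1c(-c1ccoc1)cn2[C@@H]1O[C@H](CO)[C@@H](O)[C@H]1O`: > 100000 nM (a limit)
- Compound 2 `Cc1ncnc2c1c(-c1cc3ccccc3o1)cn2[C@@H]1O[C@H](CO)[C@@H](O)[C@H]1O`: 84400 nM
- Compound 3 `Nc1nc2c(c(-c3ccco3)cn2[C@@H]2O[C@H](CO)[C@@H](O)[C@H]2O)c(=O)[nH]1`: > 100000 nM (a limit)

Compound 3 has no exact number, only the limit > 100000 nM. It is not alone there, as the values gather at one point: the limit of > 100000 nM in this assay, at which 2 of the 3 values shown sit. Compound 2 is the only one of the three with an exact reading, at 84400 nM.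

Compound 4 `Nc1nc2c(c(-c3ccsc3)cn2[C@@H]2O[C@H](CO)[C@@H](O)[C@H]2O)c(=O)[nH]1` keeps the core of compound 3 but carries thiophen-3-yl in place of furan-2-yl on an aromatic carbon. For the measured compounds named here, no measured pair here tests a swap of this kind, so the expectation is tentative. In this assay, no change beyond the usual scatter is expected, and another reading of only a limit is the likeliest outcome. The expected size of the change is an at least 1.1-fold lower number from compound 3 to compound 4 (0.04 log units; that floor lies within the scatter). Compound 2 gives an exact reading of 84400 nM. A measurable number also remains possible for compound 4. For compound 4, the estimated value is 90000 nM, with an expected range from 40000 nM to 100000 nM.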

Compound 4, half-maximal inhibitory concentration: > 100000 nM
Compound 4 was reported as a limit; the forecaster's own chance of this, stated with the estimate: 75%; middle value at least 1.1-fold (0.04 log units) away from the limit.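

As far as these compounds go, compound 3 and compound 4 are both reported only as limits, so no step can be read between them, and the effect of thiophen-3-yl in place of furan-2-yl stays unknown. Still open, from the compounds shown here alone, is whether either group on this core would give an exact number in this assay.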